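Carbamate Variation on a Piperidine Ether Scaffold

A few compounds are considered here, and "the series" means these few. Any claim that something is new, unique, unknown or untested is made for them only; others in the source may bear on it.

compound 1 `CC(C)(C)OC(=O)N1CCC(Oc2ncnc3c2CCN3c2ccc(S(C)(=O)=O)cc2F)CC1`: 20 nM
compound 2 `CC(C)(C)COC(=O)N1CCC(Oc2ncnc3c2CCN3c2ccc(S(C)(=O)=O)cc2F)CC1`: 39.8 nM

The two measured compounds share one core and differ only in the group on the oxygen next to the carbonyl group. In a functional assay on CHO-K1 cells for agonist activity at Glucose-dependent insulinotropic receptor (Homo sapiens), read by a luciferase reporter, with a stated time of 5 h (a lower number here means that less compound is needed, a higher number that more compound is needed for the effect), compound 1 gives 20 nM and compound 2 gives 39.8 nM. On the numbers shown, compound 2 stands at the upper one of the two, with compound 1 as its nearest neighbour; the single step between them, a 2.0-fold higher number from compound 1 to compound 2 (0.30 log units; within the scatter), lies within the scatter, so no order between them can be claimed.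

Compound 3 `COCCOC(=O)N1CCC(Oc2ncnc3c2CCN3c2ccc(S(C)(=O)=O)cc2F)CC1` follows from compound 2 by this change: methoxymethyl in place of tert-butyl on a saturated chain carbon bound to an oxygen next to a carbonyl group. Going by the values given here, only one measured step bears on it, the exchange of tert-butyl for neopentyl from compound 1 to compound 2, and that step stayed within the scatter. It speaks to a different exchange than the one here, so it guides the expectation only loosely. The expected step is a 1.1-fold higher number from compound 2 to compound 3 (0.05 log units; within the scatter) in this assay, with no direction beyond the scatter claimed. Compound 3 is therefore estimated at 45 nM, with a range from 13 nM to 150 nM.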

Compound 3, half-maximal effective concentration: 316 nM
Compound 3: the middle estimate sits 7.0-fold (0.85 log units) below what was measured, outside the stated range (above it).
By their numbers in this assay, from the lowest: compounds 1 and 2 (each within the scatter of the next); then compound 3.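

In this assay, the group at this position now proves able to shift the number: the exchange of tert-butyl for neopentyl had stayed within the scatter, whereas methoxymethyl in place of tert-butyl on a saturated chain carbon bound to an oxygen next to a carbonyl group gives a 7.9-fold higher number from compound 2 to compound 3 (0.90 log units; beyond the scatter). Read from the other end of the series, 2-methoxyethyl in place of tert-butyl on an oxygen next to a carbonyl group gives a 16-fold higher number from compound 1 to compound 3 (1.20 log units; beyond the scatter), so compound 3 is the least potent of the three, with its steps to both others printed as beyond the scatter. The entering group carries an oxygen and a hydrogen-bond acceptor that tert-butyl lacks, but nothing measured here accounts for the rise.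

With only one oxygen-bearing chain among the compounds shown, the presence of that oxygen cannot be separated from the loss of the branched carbon end of the group. As far as these compounds go, whether a plain butyl chain, a longer chain ending in a methoxy group, or a chain ending in an amine would stay with compound 1 and compound 2 or rise towards compound 3 remains open.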